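The compounds below may be only part of what the source reports. "The series", "measured", "known", "first", "only" and "open" are said of these compounds alone.

Measured compounds:
compound 1, `COc1ccc(-c2nc(SCC(=O)c3sc(-c4ccccc4)nc3C)nc(N)c2C#N)cc1`, 33.8% in a functional assay on U-87MG ATCC cells for antiproliferative activity against U-87 MG (Homo sapiens), read by MTT assay, with a stated time of 48 h, tested at 50 uM; a lower number here means a stronger effect, a higher number a weaker effect of the compound at the concentration tested;
compound 2, `COc1ccc(-c2nc(C)c(C(=O)CSc3nc(N)c(C#N)c(-c4ccccc4)n3)s2)cc1`, 16.5%;
compound 3, `Cc1nc(-c2ccccc2)sc1C(=O)CSc1nc(N)c(C#N)c(-c2ccc(Cl)cc2)n1`, 44.3%.

Compound 3 stands highest of the three numbers in this assay. Its nearest neighbour is compound 1, which lies lower by a margin beyond the scatter, and compound 2 lies furthest below it. Compound 4, `Cc1nc(-c2ccccc2)sc1C(=O)CSc1nc(N)c(C#N)c(-c2ccccc2)n1`, has not yet been measured in this assay. It differs from compound 3 in one place: hydrogen in place of chloro on an aromatic carbon.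

For the measured compounds named here, only one measured step touches the same position. Going from compound 1 to compound 3 the substituent on that aromatic carbon changed from methoxy to chloro, and a number 10.5 percentage points higher from compound 1 to compound 3 (beyond the scatter). That step shows the position matters beyond the scatter, but it does not say where a bare hydrogen falls relative to chloro or methoxy. Compound 2 carries a plain phenyl on the shared core, as compound 4 does, but its methoxy sits on the other aromatic ring, so no single-step comparison with compound 4 is available; its value can only be noted as the lowest of the three.

With that, the expected step is uncertain in direction; a modest fall from the high number of compound 3 is thought somewhat more likely than a rise, so the estimate is a number 9.3 percentage points lower from compound 3 to compound 4 (within the scatter). Compound 4 is therefore expected to give about 35%, within a range from 18% to 52%.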

Compound 4, a percentage reported as activity, at one concentration (the size of the read-out at that concentration, not a potency): 26.3%
Compound 4: middle estimate off by 8.7 percentage points, on the high side; measured number inside the range.
By their numbers in this assay, from the lowest: compounds 2, 4 and 1 (each within the scatter of the next, the first and the last beyond it); then compound 3.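

In this assay, for the compounds shown here, the change from 4-chlorophenyl to phenyl gives a number 18 percentage points lower from compound 3 to compound 4 (beyond the scatter), which supplies the direct comparison of chloro with hydrogen at this position that the earlier compounds lacked. Hydrogen and methoxy on this same aromatic carbon are not separated, with a number 7.5 percentage points lower from compound 1 to compound 4 (within the scatter), so among the three substituents tried here, chloro alone stands apart from the other two by more than the scatter. On the other aromatic ring, the change of methoxy to hydrogen gives a number 9.8 percentage points higher from compound 2 to compound 4 (within the scatter), so neither methoxy placement is separated from compound 4 in this assay. Nothing available here explains why chloro stands apart from hydrogen and methoxy at this position.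

From the compounds shown here alone, it remains open whether a bromo group, a trifluoromethyl group or an amine on this aromatic carbon would fall with chloro or with hydrogen and methoxy. Also open, going by these compounds, is how chloro would behave on the other aromatic ring, and whether these differences at a single concentration would hold across a range of concentrations.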